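This account rests on a few compounds, and the source may have more. Where it says the series, first, only, none or still open, it means among the compounds named here.

In a functional assay on HeLa cells (Homo sapiens) for antiproliferative activity, read by MTT assay, with a stated time of 72 h (a higher number here means a weaker inhibitor, a lower number a stronger inhibitor), the measured compounds read as follows, and each value is a limit:

compound 1 `COc1cccc(-c2ncnn2-c2cc(OC)c(OC)c(OC)c2)c1` gives > 10000 nM as a limit
compound 2 `COc1cc(-n2ncnc2-c2ccccc2)cc(OC)c1OC` gives > 10000 nM as a limit
compound 3 `COc1cc(-n2ncnc2-c2cccc(Cl)c2)cc(OC)c1OC` gives > 10000 nM as a limit

Compound 3 has no readable number of its own and stands only at the limit of > 10000 nM in this assay, at which 3 of the 3 values shown sit, in this small series. Compound 4 `COc1ccccc1-c1ncnn1-c1cc(OC)c(OC)c(OC)c1` has not yet been measured. It carries 2-methoxyphenyl in place of 3-chlorophenyl on an aromatic carbon of a five-membered aromatic ring with 3 nitrogen 2-methoxyphenyl in place of 3-chlorophenyl on an aromatic carbon and keeps the rest of compound 3 unchanged.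

Among the measured compounds shown here, three measured steps bear on this change, since each swaps a group on that same aryl ring. They are a step that the two limits leave unreadable from compound 1 to compound 2 and a step that the two limits leave unreadable from compound 1 to compound 3 and a step that the two limits leave unreadable from compound 2 to compound 3 and none of them has a size that could be carried over. For the measured compounds named here, no step of known size or direction can therefore be expected in this assay and the working expectation is none beyond the scatter. The expected move is a number no higher from compound 3 to compound 4 (the limit leaves the size open) and a report of a limit alone is the likeliest outcome. Compound 4 is estimated at 10000 nM with an expected range from 3000 nM to 30000 nM in this assay.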

Compound 4, half-maximal inhibitory concentration: > 10000 nM
Compound 4 ended at the assay's limit (the forecaster's own chance of this, stated with the estimate: 85%); the middle value sits exactly at the limit.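

In this assay compound 4 gives > 10000 nM, which is a limit. Among the compounds shown here, no step from compound 1, compound 2 or compound 3 to compound 4 can be read, as each pair has a limit at both ends. The compounds shown leave open whether any aryl group on the shared core would give a readable number, with the whole series resting at: the limit of > 10000 nM in this assay, at which 4 of the 4 values shown sit.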